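Methyl to Ethyl on the Ring Amine of Compound 3

A few compounds are considered here, and "the series" means these few. Any claim that something is new, unique, unknown or untested is made for them only; others in the source may bear on it.

Compound 1: `CCN1CC[C@@]2(OC)OC(N)=C(C#N)[C@@H](c3ccc(Br)cc3)[C@@H]2C1`, 13200 nM
Compound 2: `CCN1CC[C@@]2(OC)OC(N)=C(C#N)[C@@H](c3ccc(Cl)cc3Cl)[C@@H]2C1`, 27100 nM
Compound 3: `CO[C@@]12CCN(C)C[C@H]1[C@H](c1ccc(C)cc1)C(C#N)=C(N)O2`, 13200 nM

In a functional assay on trachea (Cavia porcellus) (a lower number here means a stronger inhibitor, a higher number a weaker inhibitor), compound 3 stands level with compound 1 at the digits shown, and these two together give the lowest of the three numbers; compound 2 sits higher. Among the compounds with values here, the only measured step, a 2.1-fold higher number from compound 1 to compound 2 (0.31 log units; beyond the scatter), concerns the aryl group on the saturated ring carbon and says nothing about the substituent on the ring amine.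

Compound 4, `CCN1CC[C@@]2(OC)OC(N)=C(C#N)[C@@H](c3ccc(C)cc3)[C@@H]2C1`, differs from compound 3 by methyl in place of hydrogen on a saturated chain carbon bound to an amine nitrogen in a ring. Within the data shown here, no measured step covers this change directly. The closest comparison is indirect: compound 1 carries the ethyl group and gives 13200 nM, matching compound 3 despite a different aryl group. On that basis compound 4 is expected to show no change beyond the scatter, a 1.0-fold lower number from compound 3 to compound 4 (0.01 log units; within the scatter). The estimate for compound 4 in this assay is 13000 nM, with a range from 5000 nM to 35000 nM.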

Compound 4, half-maximal inhibitory concentration: 16800 nM
Estimate against measurement, compound 4: 1.3-fold (0.11 log units) below, and the stated range covers the measured number.
By their numbers in this assay, from the lowest: compounds 1, 3, 4 and 2 (each within the scatter of the next, the first and the last beyond it).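

In this assay the change from methyl to ethyl on the ring amine can now be read directly with the 4-methylphenyl group held fixed, as a 1.3-fold higher number from compound 3 to compound 4 (0.10 log units; within the scatter) and so no shift that can be told from scatter at this position. With ethyl held on the amine, methyl in place of bromo on an aromatic carbon gives a 1.3-fold higher number from compound 1 to compound 4 (0.10 log units; within the scatter) and 4-methylphenyl in place of 2,4-dichlorophenyl gives a 1.6-fold lower number from compound 2 to compound 4 (0.21 log units; within the scatter) and thus compound 4 stands within the scatter of both compound 1 and compound 2, though those two differ beyond it. No measurement shown offers an explanation for these numbers.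

The compounds shown leave open whether a longer chain such as propyl, or a benzyl group, on the ring amine would stay at this level. They also leave open how a free amine hydrogen there would read against methyl and ethyl.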